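Amine substituent variation in a receptor binding series

A few compounds are considered here, and "the series" means these few. Any claim that something is new, unique, unknown or untested is made for them only; others in the source may bear on it.

Measured compounds:
Compound 1 `CCN(CCC#N)c1nc(C)nc2c(-c3c(C)cc(OC)cc3OC)c(C)nn12` gives 2.48 nM in an assay on cell membranes for displacement of a labelled ligand from corticotropin-releasing factor receptor 1 (Rattus norvegicus); on this read-out higher numbers stand for weaker inhibition and lower numbers for stronger inhibition.
Compound 2 `CCN(CC)c1nc(C)nc2c(-c3c(C)cc(OC)cc3OC)c(C)nn12` gives 1.2 nM in this assay.
Compound 3 `CCCC(C)Nc1nc(C)nc2c(-c3c(C)cc(OC)cc3OC)c(C)nn12` gives 2.14 nM in this assay.

Compound 3 stands second highest of the three numbers; its nearest neighbour is compound 1 and its furthest is compound 2, and both separations are within the scatter. Going by the values given here, the only step beyond the scatter in the set is a 2.1-fold lower number from compound 1 to compound 2 (0.32 log units; beyond the scatter), a modest one. The steps that touch compound 3 directly, a 1.2-fold lower number from compound 1 to compound 3 (0.06 log units; within the scatter) and a 1.8-fold higher number from compound 2 to compound 3 (0.25 log units; within the scatter), both lie within the scatter.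

Compound 4 `CCCN(c1nc(C)nc2c(-c3c(C)cc(OC)cc3OC)c(C)nn12)C1CC1` differs from compound 3 in one place: cyclopropyl(propyl)amino in place of (1-methylbutyl)amino on an aromatic carbon. Compound 4 thus has no hydrogen-bond donor on the amine, as compound 2 has none, whereas compound 3 has one. Among the compounds with values here, three amine variants on the shared core have kept the numbers in this assay in a narrow band, the one change beyond the scatter being the exchange of cyano for hydrogen from compound 1 to compound 2. Within the data shown here, no measured step tests a ring on the amine. The expectation for compound 4 is therefore a step of a 1.3-fold lower number from compound 3 to compound 4 (0.13 log units; within the scatter), not beyond the scatter, leaning toward a lower number because compound 2 gives 1.2 nM as the other compound without a donor. The estimate for compound 4 is 1.6 nM, with a range from 0.6 nM to 4.5 nM.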

Compound 4, half-maximal inhibitory concentration: 1.48 nM
For compound 4 the middle estimate is 1.1-fold (0.03 log units) above the measured one, within the range that was stated.
By their numbers in this assay, from the lowest: compounds 2, 4, 3 and 1 (each within the scatter of the next, the first and the last beyond it).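

Exchanging (1-methylbutyl)amino for cyclopropyl(propyl)amino, which brings the first three-membered ring onto the amine and removes the hydrogen-bond donor, gives a 1.4-fold lower number from compound 3 to compound 4 (0.16 log units; within the scatter) in this assay; at this aromatic carbon between two ring nitrogen atoms, the two changes taken together leave the number within the scatter. Going by these compounds alone, compound 4 also stays within the scatter of the other two amines, with a 1.2-fold higher number from compound 2 to compound 4 (0.09 log units; within the scatter) against diethylamino and a 1.7-fold lower number from compound 1 to compound 4 (0.22 log units; within the scatter) against (2-cyanoethyl)(ethyl)amino, so a 2.1-fold lower number from compound 1 to compound 2 (0.32 log units; beyond the scatter) remains the only step beyond the scatter in the set. Nothing available bears on the reason these amines give such close numbers.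

As far as these compounds go, the step from compound 3 to compound 4 changes the ring and the donor at once, so the share of each stays open; dipropylamino and cyclopropylamino on the same carbon would separate the two. From the compounds shown here alone, how far the narrow band extends also remains open for amines with a larger ring, such as cyclohexyl, or with ether oxygens, such as bis(2-methoxyethyl)amino.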